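The compounds below may be only part of what the source reports. "The series", "measured", "known", "first", "only" and "open" are said of these compounds alone.

Working notes on the series. Compound 1 `C=C(c1ccc(C(=O)NCCCCCCNC(=O)c2ccc(C(=O)Nc3ccc4c(c3)C(C)(C)CCC4(C)C)cc2)cc1)c1cc2c(cc1C)C(C)(C)CCC2(C)C` gives 70700 nM in a functional assay on HL-60 cells (Homo sapiens) for inhibition, read by MTT assay, with a stated time of 48 h; on this read-out lower numbers stand for stronger inhibition and higher numbers for weaker inhibition. Compound 3 `C=C(c1ccc(C(=O)OCCOC(=O)c2ccc(C(=O)Nc3ccc4c(c3)C(C)(C)CCC4(C)C)cc2)cc1)c1cc2c(cc1C)C(C)(C)CCC2(C)C` gives 30700 nM in this assay. Compound 2 `CCCC(=O)OCCCCOC(=O)c1ccc(C(=O)Nc2ccc3c(c2)C(C)(C)CCC3(C)C)cc1` gives 7320 nM in this assay, the lowest of the three numbers; its gap to compound 3 and its larger gap to compound 1 both lie beyond the usual scatter of repeated measurements. No pair among these three compounds differs in a single place, so no step between measured compounds can be read off.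

Compound 4 `CCCC(CCC)C(=O)OCCOC(=O)c1ccc(C(=O)Nc2ccc3c(c2)C(C)(C)CCC3(C)C)cc1` has not yet been measured. It differs from compound 2 in one place: ((1-propylbutyl)carbonyl)oxy in place of 2-((propylcarbonyl)oxy)ethyl on a saturated chain carbon, two bonds along the chain from an oxygen next to a carbonyl group. Among the measured compounds shown here, both compounds keep the core of compound 2, and nothing among the measured compounds shows how a change of this kind moves the read-out. The expectation is a step from compound 2 to compound 4 of a 1.1-fold higher number from compound 2 to compound 4 (0.04 log units; within the scatter) in this assay, not beyond the scatter in either direction. Compound 4 is thus expected to give about 8000 nM in this assay, estimated to fall between 2500 nM and 25000 nM.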

Compound 4, half-maximal inhibitory concentration: 256000 nM
For compound 4 the middle estimate is 32-fold (1.51 log units) below the measured one; the whole stated range lies below it.
By their numbers in this assay, from the lowest: compound 2; then compound 3; then compound 1; then compound 4.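

In this assay, this place on a saturated chain carbon, two bonds along the chain from an oxygen next to a carbonyl group, proves sensitive: a 35-fold higher number from compound 2 to compound 4 (1.54 log units; beyond the scatter) follows when ((1-propylbutyl)carbonyl)oxy replaces 2-((propylcarbonyl)oxy)ethyl. The two groups match in hydrogen-bond donors, hydrogen-bond acceptors, oxygen count, double bonds outside aromatic rings and net charge, and neither has a ring, so a difference confined to their carbon parts, 8 carbon atoms against 6, accompanies a step of this size. No evidence at hand bears on the cause of this step.

The compounds shown do not separate the contribution of the 1-propylbutyl group from that of the altered chain as a whole. Also open, on these data alone, is whether a longer unbranched chain, an amine or a carboxylic acid at this place would stay close to compound 2 or move the number as far as compound 4 does.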